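The compounds below may be only part of what the source reports. "The series", "measured", "known", "first", "only" and "open" are said of these compounds alone.

Within the data shown here, in a functional assay on P388 cells (Mus musculus) for cytotoxicity (on this read-out higher numbers stand for an effect only at larger amounts of compound and lower numbers for an effect already at smaller amounts), compound 1 (`CCOc1cc(-c2ccccc2)nc2ccccc12`) gives 6 ug/mL as the higher of the two numbers so far, and compound 2 (`Oc1ccc2c(O)cc(-c3ccccc3)nc2c1`) gives 0.81 ug/mL as the lower number, a gap beyond the usual scatter. Compound 3 (`CCCOc1cc(-c2ccccc2)nc2ccccc12`) has yet to be measured in this assay and differs from compound 1 by a single change. That change (methyl in place of hydrogen on a saturated chain carbon, two bonds along the chain from an oxygen on an aromatic ring) is methyl in place of hydrogen on a saturated chain carbon, two bonds along the chain from an oxygen on an aromatic ring, which turns ethoxy to propoxy. Among the measured compounds shown here, no measured pair shows a change of this kind, and compound 2 differs from compound 1 in more than one place. In this assay a small step with no firm direction is expected, most likely none beyond the scatter, and the estimated move (a 1.2-fold lower number from compound 1 to compound 3 (0.08 log units; within the scatter)) stays modest. For compound 3 the expected value is 5 ug/mL with an estimated range of 2 ug/mL to 12 ug/mL for now.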

Compound 3, half-maximal effective concentration: 6.9 ug/mL
Beside the measured number, compound 3's estimate is 1.4-fold (0.14 log units) below it; low and high end bracket the measured number.
By their numbers in this assay, from the lowest: compound 2; then compounds 1 and 3 (each within the scatter of the next).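

In this assay, the change from ethoxy to propoxy gives a 1.2-fold higher number from compound 1 to compound 3 (0.06 log units; within the scatter), the first reading of a change of this kind among these compounds. Methyl in place of hydrogen on a saturated chain carbon, two bonds along the chain from an oxygen on an aromatic ring, therefore leaves compound 1 and compound 3 indistinguishable on this read-out, so on the shared core this position accepts the extra methyl without a shift beyond the scatter. No measured property of these compounds bears on this result.

As far as these compounds go, whether a longer chain such as butoxy, or an amine in place of the propoxy, would shift the number remains open. Compound 2 differs from compound 1 in more than one place, so no single change can be tied to the lower number of compound 2, 0.81 ug/mL.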